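Two indole cores, one benzyl change, and an open question

The compounds below may be only part of what the source reports. "The series", "measured", "known", "first", "only" and "open" are said of these compounds alone.

Compound 1, `COc1ccc2c(c1)c(C1CC(c3ccncc3)=NO1)cn2Cc1ccc(Cl)cc1`: in a functional assay on LNCaP C4-2 cells (Homo sapiens) for inhibition, read by MTT assay, with a stated time of 48 h (on this read-out higher numbers stand for weaker inhibition and lower numbers for stronger inhibition), compound 1 gives > 100000 nM, a limit.
Compound 2, `COc1ccc2c(C3CC(c4ccncc4)=NO3)c[nH]c2c1`: in this assay compound 2 gives 3500 nM.
Compound 3, `COc1ccc2[nH]cc(C3CC(c4ccncc4)=NO3)c2c1`: in this assay compound 3 gives > 100000 nM, a limit.

Among the compounds with values here, compound 2 is the only member of the set with a number rather than a limit. Compound 2 and compound 3 share the same atoms joined differently; the difference between the two cores is not broken down here. From compound 3 to compound 1 the change is 4-chlorobenzyl in place of hydrogen on an aromatic nitrogen. The step that the two limits leave unreadable from compound 3 to compound 1 cannot be read because of the limit of > 100000 nM in this assay, at which 2 of the 3 values shown sit.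

Compound 4, `COc1ccc2c(C3CC(c4ccncc4)=NO3)cn(Cc3ccc(Cl)cc3)c2c1`, is not yet measured. Within the data shown here, it arises from compound 2 by 4-chlorobenzyl in place of hydrogen on an aromatic nitrogen, the same change as the one from compound 3 to compound 1, made at a place described in the same words. In this assay, among the measured compounds shown here, compound 4 is therefore the second example of this change, but the first example gives no guidance on its size. The expectation for compound 4 rests only on the value of compound 2, 3500 nM, with a broad margin in both directions; the estimated step is a 2.6-fold higher number from compound 2 to compound 4 (0.41 log units; beyond the scatter). Compound 4 is expected to give about 9000 nM, estimated to fall between 1500 nM and 60000 nM.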

Compound 4, half-maximal inhibitory concentration: > 100000 nM
Compound 4: only a limit was reported; the forecaster's own chance of this, stated with the estimate: 25%; middle value at least 11-fold (1.04 log units) away from the limit.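

In this assay, placing 4-chlorobenzyl instead of hydrogen on the aromatic nitrogen of compound 2 gives an at least 28-fold higher number from compound 2 to compound 4 (1.45 log units; beyond the scatter), so on this core the change goes with much weaker inhibition, and the size printed is only a lower bound. Compound 4 gives > 100000 nM, a limit. This does not show that the change acts alike on the two cores, since the step from compound 3 to compound 1 cannot be read and the only step with any stated size is the new one, so the two sizes cannot be compared: the limit of > 100000 nM in this assay, at which 3 of the 4 values shown sit.

Compound 2 stays the only compound with a number, at 3500 nM, and with a single group tested on its aromatic nitrogen, the compounds shown do not tell whether the weaker inhibition belongs to 4-chlorobenzyl in particular or to any group replacing that hydrogen. From the compounds shown here alone, it remains open whether a methyl group, an unsubstituted benzyl group, or a longer chain ending in an amine or a carboxylic acid on that nitrogen would keep a measurable value in this assay.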